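Swapping Phenyl for Thiophene on the Carbonyl Carbon

The compounds below may be only part of what the source reports. "The series", "measured", "known", "first", "only" and "open" are said of these compounds alone.

Compound 1 `COc1ccc(-c2cc3ccccc3nc2/C=C/C(=O)c2ccccc2)cc1` is tested in a functional assay on MCF7 cells (Homo sapiens) for antiproliferative activity, read by XTT assay, with a stated time of 72 h (on this read-out higher numbers stand for weaker inhibition and lower numbers for stronger inhibition), where compound 1 gives 4040 nM. That is the second highest of three numbers. Compound 2 `COc1ccc(-c2cc3ccccc3nc2/C=C/C(=O)c2ccc(OC)cc2OC)cc1` gives 6260 nM, and a 1.5-fold higher number from compound 1 to compound 2 (0.19 log units; within the scatter). Compound 3 `COc1ccc(-c2cc3ccccc3nc2/C=C/C(=O)c2ccco2)cc1` gives 710 nM, and a 5.7-fold lower number from compound 1 to compound 3 (0.76 log units; beyond the scatter); likewise an 8.8-fold lower number from compound 2 to compound 3 (0.95 log units; beyond the scatter). Compound 4 `COc1ccc(-c2cc3ccccc3nc2/C=C/C(=O)c2cccs2)cc1` differs from compound 1 at one spot: thiophen-2-yl in place of phenyl on a carbonyl carbon. Going by the values given here, the step that bears on this is the one from compound 1 to compound 3, where another five-membered aromatic ring with one hetero atom replaced phenyl on the carbonyl carbon and the number dropped modestly. Compound 4 is therefore expected to show a moderately lower number than compound 1, a 2.7-fold lower number from compound 1 to compound 4 (0.43 log units; beyond the scatter). The estimate for compound 4 in this assay is 1500 nM, with a range from 500 nM to 4500 nM.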

Compound 4, half-maximal inhibitory concentration: 1030 nM
Estimate against measurement, compound 4: 1.5-fold (0.16 log units) above; the measured number falls inside the stated range.
By their numbers in this assay, from the lowest: compounds 3 and 4 (each within the scatter of the next); then compounds 1 and 2 (each within the scatter of the next).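

In this assay, a second five-membered aromatic ring with one hetero atom also gives a lower number on the carbonyl carbon than either six-membered ring, with a 3.9-fold lower number from compound 1 to compound 4 (0.59 log units; beyond the scatter) and a 6.1-fold lower number from compound 2 to compound 4 (0.78 log units; beyond the scatter). The two five-membered rings cannot be told apart, with a 1.5-fold higher number from compound 3 to compound 4 (0.16 log units; within the scatter), so the gain is not unique to furan-2-yl. No measurement at hand explains this gain. From the compounds shown here alone, it remains open whether pyridin-2-yl, a six-membered aromatic ring containing nitrogen, would behave like phenyl or like thiophen-2-yl. The same question applies to a non-aromatic group such as cyclohexyl.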